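Chlorine Placement on the Benzyl Group

The source may hold more compounds than are shown below. What is called first, only, known or untested is meant among the compounds shown, and "the series" means these compounds.

Compound 1 `Cc1ccc(CSc2cc(Cl)c(C)cc2S(=O)(=O)/N=C(\N)n2nc(C)cc2-c2ccccc2)cc1` gives 28000 nM in a functional assay on HCT-116 cells (Homo sapiens) for cytotoxicity, read by MTT assay, with a stated time of 72 h; on this read-out lower numbers stand for stronger inhibition and higher numbers for weaker inhibition.
Compound 2 `Cc1cc(-c2ccccc2)n(/C(N)=N/S(=O)(=O)c2cc(C)c(Cl)cc2SCc2cccc(Cl)c2)n1` gives 18000 nM in this assay.

Compound 2 holds the lower of the two numbers, yet the step of a 1.6-fold lower number from compound 1 to compound 2 (0.19 log units; within the scatter) lies within the scatter. Compound 3 `Cc1cc(-c2ccccc2)n(/C(N)=N/S(=O)(=O)c2cc(C)c(Cl)cc2SCc2ccc(Cl)cc2)n1` differs from compound 2 by 4-chlorophenyl in place of 3-chlorophenyl on a saturated chain carbon bound to a sulfur. Among the compounds with values here, the only step that bears on it is a 1.6-fold lower number from compound 1 to compound 2 (0.19 log units; within the scatter), which also changed the aryl group on that carbon and stayed within the scatter. Compound 3 is therefore expected to show no step beyond the scatter, no change at the digits printed from compound 2 to compound 3 (within the scatter). Compound 3 is estimated at 18000 nM, between 8000 nM and 40000 nM.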

Compound 3, half-maximal inhibitory concentration: 7000 nM
Compound 3: the middle estimate sits 2.6-fold (0.41 log units) above what was measured, outside the stated range (below it).
By their numbers in this assay, from the lowest: compound 3; then compounds 2 and 1 (each within the scatter of the next).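

Moving the chlorine matters at this position in this assay: 4-chlorophenyl in place of 3-chlorophenyl on a saturated chain carbon bound to a sulfur gives a 2.6-fold lower number from compound 2 to compound 3 (0.41 log units; beyond the scatter) and is the first step here beyond the scatter. The second new step, chloro in place of methyl on an aromatic carbon, gives a 4.0-fold lower number from compound 1 to compound 3 (0.60 log units; beyond the scatter) and shows that 4-chlorophenyl also differs from 4-methylphenyl at this position. No measurement shown accounts for either step.

On these data alone, whether 4-methoxyphenyl or 4-aminophenyl on that carbon would give a lower number remains open. So does the effect of a longer chain between the sulfur and the ring.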